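A few compounds are considered here, and "the series" means these few. Any claim that something is new, unique, unknown or untested is made for them only; others in the source may bear on it.

Working notes on the series.

Compound 1 `O=C(Nc1ccc(Oc2ccnc3[nH]ccc23)c(F)c1)c1cc2cccnc2n(-c2ccc(Br)cc2)c1=O` is the reference point: in a functional assay on HT-29 cells (Homo sapiens) for antiproliferative activity, read by MTT assay, with a stated time of 72 h (on this read-out higher numbers stand for weaker inhibition and lower numbers for stronger inhibition), compound 1 gives 120 nM. Compound 2 `O=C(Nc1ccc(Oc2ccnc3[nH]ccc23)c(F)c1)c1cc2cccnc2n(-c2ccc(Br)cc2F)c1=O` carries one change relative to compound 1, (fluoro in place of hydrogen on an aromatic carbon), and in this assay compound 2 gives 820 nM; the step of a 6.8-fold higher number from compound 1 to compound 2 (0.83 log units; beyond the scatter) is therefore a clear loss of potency on a change of a single atom.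

Compound 3 `Cn1ccc2c(Oc3ccc(NC(=O)c4cc5cccnc5n(-c5ccccc5)c4=O)cc3F)ccnc21` sits on a core that differs from that of compound 1 in more than one place; the difference between the two cores is not broken down here. In this assay compound 3 gives 510 nM, a number close to that of compound 2 and well above that of compound 1.

Compound 4 `Cn1ccc2c(Oc3ccc(NC(=O)c4cc5cccnc5n(-c5ccc(F)cc5)c4=O)cc3F)ccnc21` is not yet measured. Its relation to compound 3 is fluoro in place of hydrogen on an aromatic carbon. Within the data shown here, this is the same kind of change as the one from compound 1 to compound 2, but not the same change: there the fluoro entered ortho to a large group and meta to a bromo group, whereas here it enters para to a large group, and the two cores are themselves different. Among the measured compounds shown here, the earlier step of a 6.8-fold higher number from compound 1 to compound 2 (0.83 log units; beyond the scatter) is the only precedent, and it points toward a weaker compound, though the shift in place makes a smaller step the more cautious expectation. For compound 4 the expected step is a 1.6-fold higher number from compound 3 to compound 4 (0.20 log units; within the scatter), resting on the value of compound 3 510 nM and on the direction of the step from compound 1 to compound 2. Compound 4 is accordingly estimated at 800 nM, with a plausible range from 300 nM to 2500 nM.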

Compound 4, half-maximal inhibitory concentration: 160 nM
Beside the measured number, compound 4's estimate is 5.0-fold (0.70 log units) above it, outside the stated range (below it).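

The same kind of change, fluoro in place of hydrogen on an aromatic carbon, does not carry over in size or direction from one core to the other in this assay: the same change on two cores in this assay, a 6.8-fold higher number (0.83 log units; beyond the scatter) from compound 1 to compound 2 and a 3.2-fold lower number (0.50 log units; beyond the scatter) from compound 3 to compound 4, 22-fold (1.34 log units) apart, beyond the scatter of two such steps. The new step, a 3.2-fold lower number from compound 3 to compound 4 (0.50 log units; beyond the scatter), shows that phenyl to 4-fluorophenyl goes with stronger inhibition on the core of compound 3, whereas the fluoro of compound 2 goes with weaker inhibition on the core of compound 1, so the direction of a step on one core cannot be assumed on the other. This does not show that the core alone decides the outcome, as the two pairs also differ in where the fluoro stands and only compound 1 and compound 2 carry a bromo group, and two pairs cannot separate these differences or support a general rule for the series.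

The compounds shown leave open whether the direction of the step follows the core or the place of the fluoro, as they hold no pair with the fluoro in the same place on both cores. Also open, going by these compounds, is how a chloro group, a methoxy group or an amine on that same carbon would read against the fluoro of compound 4.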